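A few compounds are considered here, and "the series" means these few. Any claim that something is new, unique, unknown or untested is made for them only; others in the source may bear on it.

Working notes on the series in a functional assay on KB cells (Homo sapiens) for inhibition; on this read-out lower numbers stand for stronger inhibition and higher numbers for weaker inhibition. Compound 1 (`COCCOCN1c2ncnc(N)c2C(C(=N)S)C1N`) reads > 320000 nM, which is a limit of the assay and not a number. Compound 2 (`CCCn1c(N)c(C#N)c2c(N)ncnc21`) gives 15000 nM, the only true number shown so far. Compound 3 (`N#Cc1c(N)n(Cc2ccccc2)c2ncnc(N)c12`) differs from compound 2 by phenyl in place of ethyl on a saturated chain carbon bound to an aromatic nitrogen. Going by the values given here, no step between measured compounds is available. The estimated 1.3-fold lower number from compound 2 to compound 3 (0.10 log units; within the scatter) is expected to stay within the scatter, with neither direction favoured. For compound 3 the expected value is 12000 nM, with an estimated range of 2500 nM to 60000 nM.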

Compound 3, half-maximal inhibitory concentration: 34000 nM
The estimate for compound 3 lay 2.8-fold (0.45 log units) below the measured number; the range from low to high includes it.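

Phenyl in place of ethyl on a saturated chain carbon bound to an aromatic nitrogen gives a 2.3-fold higher number from compound 2 to compound 3 (0.36 log units; beyond the scatter) in this assay, the first readable step in the series and a modest loss of inhibition. Compound 3 still gives a true number, so this position accepts an aromatic ring without the read-out reaching a limit. Nothing at hand accounts for the step. From the compounds shown here alone, whether the loss follows from the ring itself or from the larger group stays open. A longer chain or an amine at this place would help separate the two.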